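The source may report more compounds than this note shows. Statements on the series, on what has been measured and on what is new or still open speak of the compounds shown alone.

Working notes on a small set of analogues bearing a pentafluorosulfanyl-substituted anilide. Compound 1 `CC(O)(CSc1ccc(F)cc1)C(=O)Nc1cccc(S(F)(F)(F)(F)F)c1` gives 26900 nM in a functional assay on LNCaP cells (Homo sapiens) for antiproliferative activity, read by propidium iodide staining, with a stated time of 96 h; on this read-out lower numbers stand for stronger inhibition and higher numbers for weaker inhibition. Compound 2 `CC(O)(CSc1ccc(C(F)(F)F)cc1)C(=O)Nc1cccc(S(F)(F)(F)(F)F)c1` carries the change trifluoromethyl in place of fluoro on an aromatic carbon relative to compound 1; in this assay compound 2 gives 17500 nM, a step of a 1.5-fold lower number from compound 1 to compound 2 (0.19 log units; within the scatter). Compound 3 `CC(O)(CS(=O)(=O)c1ccc(F)cc1)C(=O)Nc1ccc(S(F)(F)(F)(F)F)cc1` belongs to a different core; how the core of compound 3 differs from the core of compound 1 is not broken down here. In this assay compound 3 gives 18200 nM, which sits within the scatter of both compound 1 and compound 2.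

Compound 4 `CC(O)(CS(=O)(=O)c1ccc(C(F)(F)F)cc1)C(=O)Nc1ccc(S(F)(F)(F)(F)F)cc1` is compound 3 carrying the change (trifluoromethyl in place of fluoro on an aromatic carbon). This is the same change as that from compound 1 to compound 2, made on the core of compound 3 instead; the surroundings of the place are the same in both pairs, so the two occurrences count as the same change, made in two pairs. Within the data shown here, the only guide to its size is the earlier step of a 1.5-fold lower number from compound 1 to compound 2 (0.19 log units; within the scatter), which stays within the scatter.

Among the measured compounds shown here, for compound 4 the step in this assay is expected to be a 1.4-fold lower number from compound 3 to compound 4 (0.15 log units; within the scatter), of the same direction and modest size as the earlier one, because a 1.5-fold lower number from compound 1 to compound 2 (0.19 log units; within the scatter) is the sole precedent. Compound 4 is accordingly estimated at 13000 nM, with a range from 6000 nM to 30000 nM; a further analogue could still overturn this, as the precedent rests on a single pair.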

Compound 4, half-maximal inhibitory concentration: 20700 nM
For compound 4 the middle estimate is 1.6-fold (0.20 log units) below the measured one; the measured number falls inside the stated range.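

In this assay, trifluoromethyl in place of fluoro on the core of compound 3 gives a 1.1-fold higher number from compound 3 to compound 4 (0.06 log units; within the scatter), so the change again stays within the scatter, as it did on the core of compound 1. Although the two steps point in opposite directions, this is no evidence of a reversal between the cores, and the two occurrences do not separate: the same change on two cores in this assay, a 1.5-fold lower number (0.19 log units; within the scatter) from compound 1 to compound 2 and a 1.1-fold higher number (0.06 log units; within the scatter) from compound 3 to compound 4, 1.7-fold (0.24 log units) apart, within the scatter of two such steps. This shows that, in these two pairs, the change has no readable effect on either core, but it does not show that the change is without effect in the series or that the two cores would respond alike to a change with a larger step, as two pairs with small steps cannot resolve a small real effect of either sign or test transfer of a clear one.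

On these data alone, whether an amine, a carboxylic acid or a nitrile in place of fluoro and trifluoromethyl would give a step beyond the scatter remains open, as does how such a step would carry from one core to the other. The core of compound 1 and the core of compound 3 differ in more than one place, so the contribution of each difference between them cannot be read from these compounds.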